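Swapping the Phenoxy Group in a Pair Without Readable Potency

The source may report more compounds than this note shows. Statements on the series, on what has been measured and on what is new or still open speak of the compounds shown alone.

Compound 1, `CCCc1nnsc1CO/N=C/c1c(C)nn(C)c1Oc1ccc(F)cc1`: in a functional assay on PANC-1 cells (Homo sapiens) for inhibition, read by MTT assay, with a stated time of 48 h (a higher number here means a weaker inhibitor, a lower number a stronger inhibitor), compound 1 gives > 50000 nM, which is a limit of the assay rather than a number.
Compound 2, `CCCc1nnsc1CO/N=C/c1c(C)nn(C)c1Oc1ccc(Cl)cc1`: in this assay compound 2 gives > 50000 nM, again a limit of the assay.

Among the measured compounds shown here, the only measured step, a step that the two limits leave unreadable from compound 1 to compound 2, cannot be sized, since both ends are limits. Compound 2 therefore stands only at the limit of > 50000 nM in this assay, at which 2 of the 2 values shown sit, with no number of its own. Compound 3, `CCCc1nnsc1CO/N=C/c1c(C)nn(C)c1Oc1ccccc1C`, differs from compound 2 by 2-methylphenyl in place of 4-chlorophenyl on an oxygen on an aromatic ring. For the measured compounds named here, no measured step bears on this change, and the one step that exists is unreadable, so no direction or size of step beyond the scatter can be expected from the data. Compound 3 is expected to sit once more at the limit in this assay, estimated at 70000 nM with a range from 20000 nM to 250000 nM. The step from compound 2 to compound 3 is thus expected to be a step that the limit leaves unreadable from compound 2 to compound 3.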

Compound 3, half-maximal inhibitory concentration: > 50000 nM
Compound 3 gave a limit, no number; the forecaster's own chance of this, stated with the estimate: 80%; the middle value is on the limit's open side.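

The steps from compound 1 and compound 2 to compound 3 cannot be read, since each end is a limit rather than a number: the limit of > 50000 nM in this assay, at which 3 of the 3 values shown sit.

The compounds shown leave open whether changing the group on the oxygen alters inhibition in this assay at all.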